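A few compounds are considered here, and "the series" means these few. Any claim that something is new, unique, unknown or untested is made for them only; others in the source may bear on it.

Series notes. The three measured compounds share one core and differ only on the ring that carries the sulfonyl group. Compound 1 `O=S(=O)(NCCNc1nccc(-c2c(-c3cccc(F)c3)nc3sccn23)n1)c1ccc(Br)cc1` carries a bromo there; in a functional assay on A-375 cells (Homo sapiens) for cytotoxicity, read by MTT assay (on this read-out higher numbers stand for weaker inhibition and lower numbers for stronger inhibition), compound 1 gives 13500 nM. Compound 2 `O=S(=O)(NCCNc1nccc(-c2c(-c3cccc(F)c3)nc3sccn23)n1)c1ccc(F)cc1` has fluoro in its place, and in this assay compound 2 gives 9450 nM. Compound 3 `O=S(=O)(NCCNc1nccc(-c2c(-c3cccc(F)c3)nc3sccn23)n1)c1ccccc1` carries hydrogen on that aromatic carbon, and in this assay compound 3 gives 11000 nM, the second highest of the three numbers shown, with both of the others within the scatter of it. The recorded steps are all of this kind: a 1.4-fold lower number from compound 1 to compound 2 (0.15 log units; within the scatter), a 1.2-fold lower number from compound 1 to compound 3 (0.09 log units; within the scatter) and a 1.2-fold higher number from compound 2 to compound 3 (0.07 log units; within the scatter); none reaches beyond the scatter.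

Compound 4 `O=S(=O)(NCCCNc1nccc(-c2c(-c3cccc(F)c3)nc3sccn23)n1)c1ccccc1` has not been measured. It differs from compound 3 by ((phenylsulfonyl)amino)methyl in place of (phenylsulfonyl)amino on a saturated chain carbon, two bonds along the chain from a nitrogen on an aromatic ring. Within the data shown here, no measured step alters the saturated chain, so nothing recorded bears directly on this change; the only guide is that every step so far has stayed within the scatter. On that basis the expectation for compound 4 is no step beyond the scatter, no change at the digits printed from compound 3 to compound 4 (within the scatter), and an estimated 11000 nM in this assay, with a range from 4000 nM to 30000 nM.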

Compound 4, half-maximal inhibitory concentration: 6600 nM
Compound 4: the middle estimate sits 1.7-fold (0.22 log units) above what was measured; the measured number falls inside the stated range.
By their numbers in this assay, from the lowest: compounds 4, 2, 3 and 1 (each within the scatter of the next, the first and the last beyond it).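

In this assay, among these compounds, the saturated chain now has data behind it for the first time: ((phenylsulfonyl)amino)methyl in place of (phenylsulfonyl)amino gives a 1.7-fold lower number from compound 3 to compound 4 (0.22 log units; within the scatter), and the same chain change made together with loss of the fluoro gives a 1.4-fold lower number from compound 2 to compound 4 (0.16 log units; within the scatter), so neither step separates the chain change from the scatter. Among the compounds shown here, the only step that leaves the scatter is a 2.0-fold lower number from compound 1 to compound 4 (0.31 log units; beyond the scatter), which is modest and also removes the bromo, so it cannot be assigned to the chain alone. Nothing available accounts for any of these steps.

Still open, as far as these compounds go, is whether a longer chain continues this flat picture or moves the number clearly beyond the scatter. Also open, from the compounds shown here alone, is how an amine or a carboxylic acid on the chain would read in this assay.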